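A few compounds are considered here, and "the series" means these few. Any claim that something is new, unique, unknown or untested is made for them only; others in the source may bear on it.

Measured compounds:
- Compound 1, `S=C(Nc1ccc(Cl)cc1)OCCc1ccccc1`: in an ADME assay on MT4 cells (Homo sapiens) for cytotoxicity, read by MTT assay (a lower number here means that less compound is tolerated, a higher number that more compound is tolerated), compound 1 reached only a limit, > 100000 nM, and no number was obtained (the limit of > 100000 nM in this assay, at which 1 of the 2 values shown sits).
- Compound 2, `COc1ccc(NC(=S)OCCc2ccccc2)cc1`: in this assay compound 2 gives 36000 nM.

Among the measured compounds shown here, compound 2 therefore holds the only number in this assay; the other entry is a limit. For the measured compounds named here, the single measured step, an at least 2.7-fold lower number from compound 1 to compound 2 (0.44 log units; beyond the scatter), is a change on the aromatic ring attached to the nitrogen and leaves the rest of the shared core untouched.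

Compound 3, `COc1ccc(NC(=S)OCCc2ccncc2)cc1`, has not been measured. It differs from compound 2 at a different place: pyridin-4-yl in place of phenyl on a saturated chain carbon, two bonds along the chain from an oxygen on an unsaturated carbon. Going by the values given here, no measured step concerns this end of the molecule, so the one step seen so far gives no direct guide to what this exchange will do. With nothing pointing either way, the working expectation for compound 3 is a number close to that of compound 2, with no step beyond the scatter expected, a 1.1-fold higher number from compound 2 to compound 3 (0.05 log units; within the scatter). On that basis compound 3 is estimated at 40000 nM in this assay, expected to lie between 15000 nM and 120000 nM.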

Compound 3, half-maximal cytotoxic concentration: 59000 nM
Beside the measured number, compound 3's estimate is 1.5-fold (0.17 log units) below it, and the stated range covers the measured number.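

Among the compounds shown here, putting pyridin-4-yl in place of phenyl on a saturated chain carbon, two bonds along the chain from an oxygen on an unsaturated carbon, gives a 1.6-fold higher number from compound 2 to compound 3 (0.21 log units; within the scatter) in this assay, the first measured exchange at this end of the molecule. Adding a ring nitrogen and a hydrogen-bond acceptor at this place therefore leaves compound 2 and compound 3 indistinguishable in this read-out, while the only step beyond the scatter so far remains the one on the aromatic ring attached to the nitrogen. Compound 1 still gives only a limit and not a number, so the size of that earlier step stays open-ended: the limit of > 100000 nM in this assay, at which 1 of the 3 values shown sits.

A single exchange cannot show how far this end of the molecule tolerates change, and a carboxylic acid or an amine in place of the pyridin-4-yl, or a longer chain carrying the ring, could behave differently. The compounds shown also leave open whether chloro in place of methoxy would still give a limit when pyridin-4-yl is present, as that combination is not among them.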